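The source may report more compounds than this note shows. Statements on the series, on what has been measured and on what is new or still open speak of the compounds shown alone.

The study concerns a shared core tested for cytotoxicity in an ADME assay on HEp-2 cells (Homo sapiens) for cytotoxicity, read by MTT assay, with a stated time of 72 h; on this read-out lower numbers stand for stronger inhibition and higher numbers for weaker inhibition. Compound 1 `COc1ccc(C2=C(c3cc(OC)c(OC)c(OC)c3)C(=O)C(OC(C)=O)C2)cc1F` returns < 1 ug/mL in this assay, which is a limit rather than a number. Compound 3 `COc1ccc(C2=C(c3cc(OC)c(OC)c(OC)c3)C(=O)C(O[SiH2]C(C)(C)C)C2)cc1OC(C)C` gives 7.1 ug/mL in this assay. Compound 2 `COc1ccc(C2=C(c3cc(OC)c(OC)c(OC)c3)C(=O)CC2O[SiH2]C(C)(C)C)cc1OC` also returns a limit, > 100 ug/mL in this assay, not a measured number. On the numbers shown, compound 2 therefore stands at one of the two limits among the three results, (the limit of > 100 ug/mL in this assay, at which 1 of the 3 values shown sits), while the other limit, (the limit of < 1 ug/mL in this assay, at which 1 of the 3 values shown sits), sits at the opposite end of the range. No pair among these compounds differs in a single place, so no measured step is available.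

Compound 4 `COCOc1cc(C2=C(c3cc(OC)c(OC)c(OC)c3)C(=O)CC2O[SiH2]C(C)(C)C)ccc1OC` differs from compound 2 by methoxy in place of hydrogen on a saturated chain carbon bound to an oxygen on an aromatic ring. Since compound 2 shows only the limit > 100 ug/mL in this assay, there is no number from which a step could be counted. Compound 4 is expected to remain weak, with an estimated value of 100 ug/mL in this assay, in a range from 30 ug/mL to 300 ug/mL. The step of a number no higher from compound 2 to compound 4 (the limit leaves the size open) is thus expected to be none beyond the scatter, with a strong chance that this assay again reports only a limit for compound 4.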

Compound 4, half-maximal inhibitory concentration: 12 ug/mL
The estimate for compound 4 lay 8.3-fold (0.92 log units) above the measured number, and the stated range ends above it.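

In this assay, this position proves responsive: going from 3,4-dimethoxyphenyl to 4-methoxy-3-(methoxymethoxy)phenyl, with methoxy in place of hydrogen on a saturated chain carbon bound to an oxygen on an aromatic ring, gives an at least 8.3-fold lower number from compound 2 to compound 4 (0.92 log units; beyond the scatter). Among the compounds shown here, the earlier compounds offered no pair differing in one place, so this is the first change on the shared core that can be read on its own, and it shows that adding this small group to the existing methoxy is enough to move the result beyond the usual scatter. The true size of the step stays open because compound 2 has only a limit in this assay and not a number: the limit of > 100 ug/mL in this assay, at which 1 of the 4 values shown sits.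

The compounds shown leave open whether this shift is specific to methoxymethoxy or would also appear with another group on that oxygen, such as a longer chain or a chain ending in an amine. Steps from compound 1 or compound 3 to compound 2 or compound 4 cannot be read, since those pairs differ in more than one place.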